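Trifluoromethyl in place of methoxy: notes on compound 4

The compounds below may be only part of what the source reports. "The series", "measured", "known", "first", "only" and "open" are said of these compounds alone.

In a functional assay on HepG2 cells (Homo sapiens) for inhibition, read by sulforhodamine B assay, with a stated time of 74 h (on this read-out higher numbers stand for weaker inhibition and lower numbers for stronger inhibition), compound 1 `O=C1C=CC2(C=C1)OCC(=O)N2S(=O)(=O)c1ccc(Cl)cc1` gives 860 nM and compound 3 `COc1ccc(S(=O)(=O)N2C(=O)COC23C=CC(=O)C=C3)cc1` gives 1620 nM as its value, so these two lie within the scatter of each other. Compound 2 `O=C1C=CC2(C=C1)OCC(=O)N2S(=O)(=O)c1ccc([N+](=O)[O-])cc1` reads > 10000 nM as a limit and not a number.

Compound 4 `O=C1C=CC2(C=C1)OCC(=O)N2S(=O)(=O)c1ccc(C(F)(F)F)cc1` differs from compound 3 in one place, with trifluoromethyl in place of methoxy on an aromatic carbon, para to a large group (trifluoromethyl in place of methoxy on an aromatic carbon).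

For the measured compounds named here, three measured steps concern this same place. Methoxy in place of chloro gave a 1.9-fold higher number from compound 1 to compound 3 (0.28 log units; within the scatter) and stayed within the scatter. Nitro in place of chloro gave an at least 11-fold higher number from compound 1 to compound 2 (1.06 log units; beyond the scatter) as a large step. Methoxy in place of nitro gave an at least 6.1-fold lower number from compound 2 to compound 3 (0.79 log units; beyond the scatter) as a step beyond the scatter. Going by the values given here, both of these larger steps rest on the limit of compound 2, and no measured step involves trifluoromethyl. The range is therefore kept wide and leans towards higher numbers.

The expected step is a 1.1-fold lower number from compound 3 to compound 4 (0.03 log units; within the scatter) and so none beyond the scatter. The estimated value for compound 4 is 1500 nM with an expected range from 450 nM to 6000 nM on repeat measurement.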

Compound 4, half-maximal inhibitory concentration: 750 nM
Estimate against measurement, compound 4: 2.0-fold (0.30 log units) above, and the stated range covers the measured number.
By their numbers in this assay, from the lowest: compounds 4, 1 and 3 (each within the scatter of the next, the first and the last beyond it). At a limit, above all of these: compound 2.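

In this assay, for the compounds shown here, trifluoromethyl in place of methoxy gives a 2.2-fold lower number from compound 3 to compound 4 (0.33 log units; beyond the scatter), the first step at this place beyond the scatter that does not involve nitro, while trifluoromethyl in place of chloro gives a 1.1-fold lower number from compound 1 to compound 4 (0.06 log units; within the scatter) and so stays within it. Trifluoromethyl in place of nitro gives an at least 13-fold lower number from compound 2 to compound 4 (1.12 log units; beyond the scatter), which sets compound 2 apart from all three other compounds and confines the large loss at this place to nitro among the four groups shown. Compound 2 stands as a limit and not a number, so that step has no upper size: the limit of > 10000 nM in this assay, at which 1 of the 4 values shown sits.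

From the compounds shown here alone, whether an amine, a carboxylic acid or a longer chain at this place would read with compound 4 or with compound 2 remains open. Also open, going by these compounds, is whether the same order holds with these groups on another part of the shared core.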